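Homologation of the nitrogen-borne acid in compound 2

A few compounds are considered here, and "the series" means these few. Any claim that something is new, unique, unknown or untested is made for them only; others in the source may bear on it.

Measured compounds in a functional assay on CHO-K1 cells for antagonist activity at cysteinyl leukotriene receptor 1 (Homo sapiens), read by fluorescence and calcium flux, with stated times of 30 min and 1 h; on this read-out higher numbers stand for weaker inhibition and lower numbers for stronger inhibition:
compound 1 `Cc1c(CCCC(=O)O)c2cccc(/C=C/c3ccc(OCCCCc4c(F)cc(F)c(F)c4F)cc3)c2n1CC(=O)O` gives 1.6 nM
compound 2 `Cc1c(Cl)cccc1CCCCOc1ccc(C#Cc2cccc3c(CCCC(=O)O)c(C)n(CC(=O)O)c23)cc1` gives 0.22 nM
compound 3 `Cc1c(F)cccc1CCCCOc1ccc(/C=C/c2cccc3c(CCCC(=O)O)c(C)n(CC(=O)O)c23)cc1` gives 1.1 nM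

Compound 2 stands lowest of the three numbers; its gap to compound 3 and to compound 1 lies beyond the scatter in both cases. Going by the values given here, the one measured step, a 1.5-fold lower number from compound 1 to compound 3 (0.16 log units; within the scatter), concerns the far aryl end of the chain and stays within the scatter.

Compound 4 `Cc1c(Cl)cccc1CCCCOc1ccc(C#Cc2cccc3c(CCCC(=O)O)c(C)n(CCC(=O)O)c23)cc1` differs from compound 2 only at the acid carried on the aromatic nitrogen: carboxymethyl in place of carboxy on a saturated chain carbon bound to an aromatic nitrogen. Among the compounds with values here, no measured pair in this set changes that position, so the step from compound 1 to compound 3 offers no guidance here; it only shows that the distal aryl tolerates exchange without a shift beyond the scatter. Without a precedent, a moderate loss against the strongest number in the set is the working expectation, with wide uncertainty on either side.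

Compound 4 is therefore estimated at 1.5 nM (range 0.3 nM to 8 nM), an expected step of a 6.8-fold higher number from compound 2 to compound 4 (0.83 log units; beyond the scatter) from the value of compound 2.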

Compound 4, half-maximal inhibitory concentration in the cysteinyl leukotriene receptor 1 assay: 17 nM
Estimate against measurement, compound 4: 11-fold (1.05 log units) below; measured number above the stated range.
By their numbers in the cysteinyl leukotriene receptor 1 assay, from the lowest: compound 2; then compounds 3 and 1 (each within the scatter of the next); then compound 4.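

In the cysteinyl leukotriene receptor 1 assay, going from carboxymethyl to 2-carboxyethyl at the nitrogen-bound acid gives a 77-fold higher number from compound 2 to compound 4 (1.89 log units; beyond the scatter), so this position responds strongly to chain length, whereas the earlier exchange at the far aryl end gave only a 1.5-fold lower number from compound 1 to compound 3 (0.16 log units; within the scatter). In a physicochemical assay for permeability, using PAMPA, with a stated time of 4 h, at pH 7.4, tested at 50 uM (on this read-out higher numbers stand for higher permeability and lower numbers for lower permeability), compound 2 gives 3.2 10^-6 cm/s and compound 4 gives 3 10^-6 cm/s, and the same change gives a 1.1-fold lower number from compound 2 to compound 4 (0.03 log units; within the scatter), so the large shift in receptor read-out comes with no shift beyond the scatter in apparent permeability. Nothing available here accounts for the loss at the receptor.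

Going by these compounds, it remains open how a tetrazole in place of the carboxylic acid, or a still longer or branched chain, would read at this position. On these data alone, it is also open whether the same change would cost as much on compound 3.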